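Swapping the Aryl Amine of Compound 3 for a Benzylic Amine

A few compounds are considered here, and "the series" means these few. Any claim that something is new, unique, unknown or untested is made for them only; others in the source may bear on it.

Measured so far:
Compound 1 `C#Cc1cccc(Nc2ncnc3ccc(NC(=O)Nc4ccc(CN5CCN(C)CC5)cc4)cc23)c1` gives 2810 nM in a functional assay on A-431 cells (Homo sapiens) for antiproliferative activity, read by MTT assay, with a stated time of 72 h; a higher number here means a weaker inhibitor, a lower number a stronger inhibitor.
Compound 2 `CN1CCN(Cc2ccc(NC(=O)Nc3ccc4ncnc(Nc5ccc(F)c(F)c5)c4c3)cc2)CC1` reaches only the limit > 10000 nM in this assay.
Compound 3 `COc1ccc(Nc2ncnc3ccc(NC(=O)Nc4ccc(CN5CCN(C)CC5)cc4)cc23)cc1Cl` gives 2010 nM in this assay.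

Compound 3 holds the lowest of the two numbers read; compound 1 stands within the scatter of it, the step being a 1.4-fold lower number from compound 1 to compound 3 (0.15 log units; within the scatter). For the measured compounds named here, the only steps that clear the scatter involve compound 2, which sits at the limit of > 10000 nM in this assay, at which 1 of the 3 values shown sits: an at least 3.5-fold higher number from compound 1 to compound 2 (0.55 log units; beyond the scatter) and an at least 4.9-fold lower number from compound 2 to compound 3 (0.69 log units; beyond the scatter). All three measured steps swap one substituted phenyl for another on a nitrogen on an aromatic ring.

Compound 4 `C[C@@H](Nc1ncnc2ccc(NC(=O)Nc3ccc(CN4CCN(C)CC4)cc3)cc12)c1ccccc1` differs from compound 3 by 1-phenylethyl in place of 3-chloro-4-methoxyphenyl on a nitrogen on an aromatic ring. Going by the values given here, no measured step swaps an aryl group for an alkyl group at this nitrogen, so the measured steps bear on it only loosely, showing that changes at this position can move the number beyond the scatter. A modest rise is expected, a 2.5-fold higher number from compound 3 to compound 4 (0.40 log units; beyond the scatter), with compound 4 estimated at 5000 nM (range 1500 nM to 20000 nM).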

Compound 4, half-maximal inhibitory concentration: > 10000 nM
Compound 4: no number, only a limit; the forecaster's own chance of this, stated with the estimate: 30%; middle value at least 2.0-fold (0.30 log units) from the limit.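

In this assay, replacing a substituted phenyl on this nitrogen with 1-phenylethyl, which brings a defined stereocentre, gives a change beyond the scatter against both compounds with a readable number: an at least 4.9-fold higher number from compound 3 to compound 4 (0.69 log units; beyond the scatter), and an at least 3.5-fold higher number from compound 1 to compound 4 (0.55 log units; beyond the scatter). Among the compounds shown, a rise at this position had so far come only from 3,4-difluorophenyl, so it is not confined to a single phenyl group joined directly to the nitrogen. Compound 4 gives only a limit, as does compound 2, so the step between them cannot be read: the limit of > 10000 nM in this assay, at which 2 of the 4 values shown sit.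

On these data alone, how far compound 4 lies past its limit remains open. So does whether a plain benzyl group, without the methyl group of 1-phenylethyl, or the opposite stereoisomer would give a readable number at this nitrogen.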